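This account rests on a few compounds, and the source may have more. Where it says the series, first, only, none or still open, it means among the compounds named here.

Measured so far, in a functional assay on HCT-15 cells (Homo sapiens) for inhibition, read by sulforhodamine B assay, with a stated time of 48 h; on this read-out lower numbers stand for higher toxicity in this test and higher numbers for lower toxicity in this test:

- compound 1, `Nc1cc(N)c2nc(-c3ccccc3)c(Sc3ccc(F)cc3)nc2c1`: 56200 nM
- compound 2, `CCOC(=O)[C@H](CCC(=O)O)NC(=O)c1ccc(Oc2nc3cc(N)cc(N)c3nc2-c2ccccc2)cc1`: < 100000 nM
- compound 3, `CCOC(=O)[C@H](CCC(=O)O)NC(=O)c1ccc(CNc2nc3cc(N)cc(N)c3nc2-c2ccccc2)cc1`: < 100000 nM

Among the compounds with values here, compound 1 is the only member of the series with a numerical result in this assay. Compound 2 gives only a limit of the assay, not a number. Compound 3 likewise gives only a limit. Within the data shown here, the picture across the three measured compounds is therefore summed up by the limit of < 100000 nM in this assay, at which 2 of the 3 values shown sit, and no step between two measured compounds can be read from the data.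

The next compound to be tested is compound 4, `Nc1cc(N)c2nc(-c3ccccc3)c(NCc3ccc(F)cc3)nc2c1`. It keeps the shared core of compound 1 and differs from it in one place: (4-fluorobenzyl)amino in place of (4-fluorophenyl)sulfanyl on an aromatic carbon. The change introduces one hydrogen-bond donor at the linking position.

Among the measured compounds shown here, with no measured step in hand, the expectation for compound 4 rests on compound 1 alone. The step from compound 1 to compound 4 is expected to stay within the usual scatter, a 1.1-fold lower number from compound 1 to compound 4 (0.05 log units; within the scatter), since the limits of compounds 2 and 3 give no direction to lean on. Compound 4 is accordingly estimated at 50000 nM in this assay, within a range from 15000 nM to 150000 nM.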

Compound 4, concentration lethal to 50% of the cells: < 100000 nM
Compound 4 gave a limit, no number; the forecaster's own chance of this, stated with the estimate: 30%; the middle value does not contradict the limit.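

In this assay, within the data shown here, compound 4 gives only a limit of the assay, < 100000 nM, so no step from compound 1 to compound 4 can be read. The series remains summed up by: the limit of < 100000 nM in this assay, at which 3 of the 4 values shown sit.

The compounds shown leave open whether (4-fluorobenzyl)amino in place of (4-fluorophenyl)sulfanyl on the shared core changes the result in this assay at all.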